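A four-membered ring gives way to (methylsulfonyl)methyl

This account rests on a few compounds, and the source may have more. Where it says the series, first, only, none or still open, it means among the compounds named here.

In an ADME assay on microsomes from liver (Mus musculus) for metabolic stability (a higher number here means that the compound lasts longer, a lower number that the compound disappears faster), compound 1 `NS(=O)(=O)CC(=O)NCCSc1nonc1/C(=N/O)Nc1cccc(Cl)c1` gives 1.26 h. Compound 2 `O=C(NCCSc1nonc1/C(=N/O)Nc1ccc(F)c(C(F)F)c1)C1CS(=O)(=O)C1` gives 0.245 h, the lower of the two numbers, and the gap between them lies beyond the usual scatter. These two compounds differ in more than one place, so their gap cannot be tied to any single change. Compound 3 `CS(=O)(=O)CC(=O)NCCSc1nonc1/C(=N/O)Nc1ccc(F)c(C(F)F)c1` differs from compound 2 in one place only: a group of 5 heavy atoms (2 carbon, 2 oxygen, 1 sulfur; no ring) in place of a group of 6 heavy atoms (3 carbon, 2 oxygen, 1 sulfur; one four-membered non-aromatic ring with 1 hetero atom), on a carbonyl carbon. The entering group is (methylsulfonyl)methyl, and the four-membered non-aromatic ring is gone. Among the measured compounds shown here, no measured pair shows this change on its own. Compound 3 shares everything else with compound 2 at 0.245 h, so that value anchors the expectation. In this assay, no step beyond the scatter is expected, with only a slight lean upward. The expected step is a 1.2-fold higher number from compound 2 to compound 3 (0.09 log units; within the scatter). Compound 3 is expected at 0.3 h, with an estimated range of 0.15 h to 0.6 h.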

Compound 3, half-life: 0.765 h
The estimate for compound 3 lay 2.6-fold (0.41 log units) below the measured number; measured number outside the range, above it.
By their numbers in this assay, from the lowest: compound 2; then compounds 3 and 1 (each within the scatter of the next).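

In this assay, putting (methylsulfonyl)methyl in place of the group with the four-membered non-aromatic ring, on a carbonyl carbon, gives a 3.1-fold higher number from compound 2 to compound 3 (0.49 log units; beyond the scatter). This shows that the half-life responds to the group at this position even though the rest of the molecule stays the same, something compounds 1 and 2 could not show, since they differ in more than one place. Nothing at hand accounts for the step, so the data tie it to no particular feature of either group.

On these data alone, it remains open whether the sulfur and its two oxygens matter at this position, or whether a plain ethyl chain or an amine on the same carbonyl carbon would give a similar number. The compounds shown also leave open whether the step would carry over to the core of compound 1, with its different aromatic substituents.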